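The source may report more compounds than this note shows. Statements on the series, on what has been measured and on what is new or still open speak of the compounds shown alone.

Working notes on the series in a functional assay on COLO 205 cells (Homo sapiens) for antiproliferative activity, read by WST assay, with a stated time of 3 days; on this read-out lower numbers stand for stronger inhibition and higher numbers for weaker inhibition.

The series is built on the shared core of compound 1 `Nc1cc(=O)[nH]c(=O)n1[C@@H]1O[C@H](CO)[C@@H](O)[C@H]1O`, which carries an amino group. In this assay compound 1 gives only a limit, > 50000 nM. Compound 2 `O=c1[nH]c(=O)n([C@@H]2O[C@H](CO)[C@@H](O)[C@H]2O)c(I)c1F` adds fluoro and an iodo group. In this assay compound 2 likewise gives only a limit, > 50000 nM. Among the compounds with values here, compound 3 `[N-]=[N+]=Nc1c(F)c(=O)[nH]c(=O)n1[C@@H]1O[C@H](CO)[C@@H](O)[C@H]1O` replaces the iodo by azido; in this assay compound 3 gives 3800 nM, the only number among the three values shown. Compounds 1 and 2 each stand at a limit of the assay, (the limit of > 50000 nM in this assay, at which 2 of the 3 values shown sit). The measured step of an at least 13-fold lower number from compound 2 to compound 3 (1.11 log units; beyond the scatter) is the only one that can be sized.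

Compound 4 `Nc1c(F)c(=O)[nH]c(=O)n1[C@@H]1O[C@H](CO)[C@@H](O)[C@H]1O` differs from compound 3 as follows: amino in place of azido on an aromatic carbon. Within the data shown here, no measured step moves from azido to amino, so the step of an at least 13-fold lower number from compound 2 to compound 3 (1.11 log units; beyond the scatter) bears on it only as a sign that the group at this carbon shifts the read-out strongly. Compound 1, which also carries amino at this carbon but lacks the fluoro, sits at the limit rather than at a number. The expected direction is therefore upward, a weakening, and the expected size is a 6.6-fold higher number from compound 3 to compound 4 (0.82 log units; beyond the scatter). Compound 4 is estimated at 25000 nM, with a range of 4000 nM to 50000 nM.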

Compound 4, half-maximal inhibitory concentration: 3300 nM
The estimate for compound 4 lay 7.6-fold (0.88 log units) above the measured number; measured number below the stated range.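

In this assay, the step of a 1.2-fold lower number from compound 3 to compound 4 (0.06 log units; within the scatter) shows that azido and amino cannot be told apart at this carbon, so the number seen for compound 3 does not depend on azido. With the fluoro group in place, an at least 15-fold lower number from compound 2 to compound 4 (1.18 log units; beyond the scatter) sets amino apart from iodo; of the three groups shown at this carbon with fluoro present, only iodo, in compound 2, stays at a limit of the assay. The step of an at least 15-fold lower number from compound 1 to compound 4 (1.18 log units; beyond the scatter) gives the first one-place reading for fluoro in place of hydrogen on the aromatic carbon, and, like the step from compound 2, it starts from a limit rather than a number, so its full size cannot be given: the limit of > 50000 nM in this assay, at which 2 of the 4 values shown sit.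

From the compounds shown here alone, whether this carbon also accepts a methylamino group, a hydroxyl or a longer chain remains open. Going by these compounds, it is also open whether chloro or a methyl group could stand in for the fluoro while keeping the amino group of compound 4.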